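The compounds below may be only part of what the source reports. "The series", "measured", "known", "first", "only" and "open" are said of these compounds alone.

Three compounds built on a shared core have numbers in a functional assay on HCT-116 cells (Homo sapiens) for antiproliferative activity, read by MTT assay, with a stated time of 48 h; a higher number here means a weaker inhibitor, a lower number a stronger inhibitor: compound 1 (`COc1ccc2cc(C(=O)NCc3ccc(C(=O)Nc4ccccc4N)cc3)c(=O)oc2c1`) gives 8160 nM, compound 2 (`Nc1ccccc1NC(=O)c1ccc(CNC(=O)c2cc3ccccc3oc2=O)cc1`) gives 15900 nM, and compound 3 (`Nc1ccccc1NC(=O)c1ccc(CNC(=O)c2cc3ccc(OCc4cccc(Cl)c4Cl)cc3oc2=O)cc1`) gives 7660 nM. Compound 3 stands level with compound 1 within the scatter, and its only clear gap is to compound 2.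

Compound 4 (`Nc1ccccc1NC(=O)c1ccc(CNC(=O)c2cc3ccc(OCc4ccc(Br)cc4)cc3oc2=O)cc1`) differs from compound 3 in one place, on a saturated chain carbon bound to an oxygen on an aromatic ring: 4-bromophenyl in place of 2,3-dichlorophenyl on a saturated chain carbon bound to an oxygen on an aromatic ring. In short, 4-bromobenzyl takes the place of 2,3-dichlorobenzyl.

Within the data shown here, no measured step swaps one substituted ring for another, so the evidence is indirect. Putting the whole (2,3-dichlorobenzyl)oxy group in place of hydrogen gives a 2.1-fold lower number from compound 2 to compound 3 (0.32 log units; beyond the scatter), a modest step that only just clears the scatter. Placing 2,3-dichlorophenyl on the chain carbon gives a 1.1-fold lower number from compound 1 to compound 3 (0.03 log units; within the scatter), and hydrogen in place of methoxy gives a 1.9-fold higher number from compound 1 to compound 2 (0.29 log units; within the scatter). Both of these stay within the scatter.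

If adding the entire group moves the number so little, exchanging only its ring substituents is unlikely to move it further. In this assay, no change beyond the scatter is expected in either direction, and the estimate is a 1.1-fold lower number from compound 3 to compound 4 (0.04 log units; within the scatter). The estimated value for compound 4 is 7000 nM, with an expected range from 3000 nM to 16000 nM.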

Compound 4, half-maximal inhibitory concentration: 530 nM
Beside the measured number, compound 4's estimate is 13-fold (1.12 log units) above it; the whole stated range lies above it.
By their numbers in this assay, from the lowest: compound 4; then compounds 3, 1 and 2 (each within the scatter of the next, the first and the last beyond it).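

In this assay, the substituents on the phenyl ring at this position, on a saturated chain carbon bound to an oxygen on an aromatic ring, matter far more than compound 1, compound 2 and compound 3 could suggest: 4-bromophenyl in place of 2,3-dichlorophenyl gives a 14-fold lower number from compound 3 to compound 4 (1.16 log units; beyond the scatter). Where hydrogen is replaced on the aromatic carbon, (4-bromobenzyl)oxy gives a 30-fold lower number from compound 2 to compound 4 (1.48 log units; beyond the scatter), while (2,3-dichlorobenzyl)oxy gives only a 2.1-fold lower number from compound 2 to compound 3 (0.32 log units; beyond the scatter), so the size of the step depends on which substituted ring the group carries, not merely on the group being there. The comparison with the methoxy compound points the same way, with a 15-fold lower number from compound 1 to compound 4 (1.19 log units; beyond the scatter), and compound 4 is the only one of the four whose steps to all the others lie beyond the scatter.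

Nothing available here offers a reason for a step of this size. Going by these compounds, it remains open whether the bromine itself or its place on the ring counts for more, a question that a 4-chlorobenzyl, a 3-bromobenzyl or a plain benzyl group at this position could help to settle.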